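The source may hold more compounds than are shown below. What is called first, only, known or untested is meant among the compounds shown, and "the series" means these compounds.

Of the compounds shown here, three built on one shared core have been measured in an assay on isolated protein for binding affinity to Leucine-rich repeat serine/threonine-protein kinase 2 (Homo sapiens), read by TR-FRET and LanthaScreen, with a stated time of 2 h; on this read-out lower numbers stand for stronger inhibition and higher numbers for weaker inhibition. Compound 1 `CN(C)c1c(C#N)c2c(N)ncnc2n1C` gives 111 nM. Compound 2 `C[C@@H]1CCCN1c1c(C#N)c2c(N)ncnc2n1C` gives 0.4 nM. Compound 3 `C[C@@H]1CCCN1c1cc2c(N)ncnc2n1C` gives 164 nM, the highest of the three numbers; it sits within the scatter of the number for compound 1 and far from the number for compound 2. Two steps link these compounds: a 280-fold lower number from compound 1 to compound 2 (2.44 log units; beyond the scatter) and a 410-fold higher number from compound 2 to compound 3 (2.61 log units; beyond the scatter).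

Compound 4 `C[C@@H]1CCCN1c1c(C(N)=O)c2c(N)ncnc2n1C` has not yet been measured. It differs from compound 3 in one place: carbamoyl in place of hydrogen on an aromatic carbon. The step that bears on this change is the removal of the cyano group, a 410-fold higher number from compound 2 to compound 3 (2.61 log units; beyond the scatter), which was large. Adding a carbamoyl group to compound 3 puts a substituent back on that carbon, so a step in the opposite direction, toward a lower number in this assay, is expected. Carbamoyl is not cyano, and for compound 4 a step smaller than the full reverse is expected, a 27-fold lower number from compound 3 to compound 4 (1.44 log units; beyond the scatter). For compound 4 the expected value is 6 nM, with a range from 1 nM to 40 nM.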

Compound 4, inhibition constant: 77 nM
Compound 4: middle estimate off by 13-fold (1.11 log units), on the low side; measured number above the stated range.
By their numbers in this assay, from the lowest: compound 2; then compounds 4, 1 and 3 (each within the scatter of the next, the first and the last beyond it).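

On this carbon, putting back just any substituent does not restore the low number: in this assay carbamoyl in place of hydrogen brings only a 2.1-fold lower number from compound 3 to compound 4 (0.33 log units; beyond the scatter) and this step is modest. Carbamoyl in place of cyano brings a 190-fold higher number from compound 2 to compound 4 (2.28 log units; beyond the scatter) and this step is large. With the 2-methylpyrrolidin-1-yl group held constant, the outcome at this position therefore depends strongly on which group sits there, and among these compounds only the nitrile gives a number close to that of compound 2.

Going by these compounds, whether another group on this carbon, such as a carboxylic acid, an acetyl group or a methyl group, would come closer to the nitrile remains open. No measurement here explains the large gap between nitrile and carbamoyl.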